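This account rests on a few compounds, and the source may have more. Where it says the series, first, only, none or still open, it means among the compounds named here.

Compound 1 `Cc1c(C(=O)Nc2c(F)cc(-c3cccc(F)c3)cc2F)nc2ccc(C(F)(F)F)cc2c1O` and compound 3 `Cc1c(C(=O)Nc2c(F)cc(-c3cccc(F)c3)cc2F)nc2ccc(C(F)(F)F)cc2c1C(=O)O` share one core and differ only in that compound 3 carries carboxy in place of hydroxy on an aromatic carbon. In a functional assay on Hep 3B2 cells (Homo sapiens) for antiproliferative activity, read by MTT assay, with a stated time of 24 h, tested at 100 ug/mL (a higher number here means a stronger effect of the compound at the concentration tested, a lower number a weaker effect), compound 1 gives 68.4%, and compound 3 gives 72.3%, so the step of a number 3.9 percentage points higher from compound 1 to compound 3 (within the scatter). Compound 2 `COc1ccc2nc(C(=O)Nc3ccc(-c4ccccc4)cc3)c(C)c(O)c2c1` rests on a different core; how its core differs from that of compound 1 is not broken down here. In this assay compound 2 gives 79.3%, which stands beyond the scatter above compound 1 but within the scatter of compound 3. Compound 4 `COc1ccc2nc(C(=O)Nc3ccc(-c4ccccc4)cc3)c(C)c(C(=O)O)c2c1` is the same change applied to compound 2: it carries carboxy in place of hydroxy on an aromatic carbon. The step is expected to be small, a number 2.7 percentage points higher from compound 2 to compound 4 (within the scatter), because a number 3.9 percentage points higher from compound 1 to compound 3 (within the scatter) stayed within the scatter. Compound 4 is therefore estimated to give 82% in this assay, between 70% and 92%.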

Compound 4, a percentage reported as inhibition, at one concentration (the size of the read-out at that concentration, not a potency): 72.5%
Compound 4: middle estimate off by 9.5 percentage points, on the high side, within the range that was stated.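

Placing carboxy where hydroxy stood on the core of compound 2 gives, in this assay, a number 6.8 percentage points lower from compound 2 to compound 4 (within the scatter). Set beside the earlier step, the change does not separate the two cores: the same change on two cores in this assay, a number 3.9 percentage points higher (within the scatter) from compound 1 to compound 3 and a number 6.8 percentage points lower (within the scatter) from compound 2 to compound 4, 10.7 percentage points apart, within the scatter of two such steps. This shows that, on these two cores, the change gave no step beyond the scatter, but two pairs cannot show that it acts alike on both or on any other core in the series.

The compounds shown leave open whether an amine or a longer chain at the same place would give a step beyond the scatter. With one concentration read, they also leave open how the compounds compare in potency.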